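Shrinking the Aryl Group Back Toward Phenyl

The compounds below may be only part of what the source reports. "The series", "measured", "known", "first", "only" and "open" are said of these compounds alone.

The shared core is carried by two measured compounds. Compound 1, `c1ccc(-c2cn3ccnc3c(-c3ccc4ncn(C5CCCCC5)c4c3)n2)cc1`, bears a phenyl group and in a functional assay on MCF7 cells (Homo sapiens) for inhibition, read by sulforhodamine B assay, with a stated time of 48 h, tested at 10 uM (on this read-out higher numbers stand for more inhibition at the one concentration tested (going by the name of the read-out) and lower numbers for less inhibition), compound 1 gives 38%. Compound 2, `c1ccc2c(-c3cn4ccnc4c(-c4ccc5ncn(C6CCCCC6)c5c4)n3)cccc2c1`, carries naphthalen-1-yl in its place, and in this assay compound 2 gives 13%. Within the data shown here, the single measured step is a number 25 percentage points lower from compound 1 to compound 2 (beyond the scatter), which leaves compound 2 as the lower of the two numbers, with compound 1 standing higher by a margin beyond the scatter.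

Compound 3, `Clc1ccc(-c2cn3ccnc3c(-c3ccc4ncn(C5CCCCC5)c4c3)n2)cc1`, is the next member. It differs from compound 2 in one place: 4-chlorophenyl in place of naphthalen-1-yl on an aromatic carbon. Among the measured compounds shown here, the only step that bears on this change is the one from compound 1 to compound 2, where replacing phenyl with naphthalen-1-yl cost a modest amount. Since 4-chlorophenyl is a single six-membered ring like the phenyl of compound 1, the change is expected to undo most of that loss. Compound 3 is therefore estimated at 35% in this assay, within 15% to 58%, meaning an expected step of a number 22 percentage points higher from compound 2 to compound 3 (beyond the scatter).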

Compound 3, a percentage reported as inhibition, at one concentration (the size of the read-out at that concentration, not a potency): 21.8%
For compound 3 the middle estimate is 13.2 percentage points above the measured one; the measured number falls inside the stated range.
By their numbers in this assay, from the lowest: compounds 2 and 3 (each within the scatter of the next); then compound 1.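

In this assay the exchange of naphthalen-1-yl for 4-chlorophenyl gives a number 8.8 percentage points higher from compound 2 to compound 3 (within the scatter), so at this position on the shared core the two groups cannot be told apart, even though one has two aromatic rings and the other only one. The comparison with the unsubstituted ring is more telling: chloro in place of hydrogen gives a number 16.2 percentage points lower from compound 1 to compound 3 (beyond the scatter), which shows that a return to a single six-membered aromatic ring does not by itself restore the number of compound 1, and that among these three compounds the plain phenyl group alone stands apart from the other two. Nothing available here explains either step.

As far as these compounds go, it remains open whether this loss belongs to chloro specifically or would also follow from another group at the same place on the phenyl ring, such as fluoro, methoxy, an amine or a carboxylic acid. It is also open whether a group on the phenyl ring exists that lifts the number above that of compound 1, since the compounds shown offer only changes that lower it.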